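A few compounds are considered here, and "the series" means these few. Any claim that something is new, unique, unknown or untested is made for them only; others in the source may bear on it.

Compound 3 `CNCc1cn(S(=O)(=O)c2ccc(F)cn2)c(-c2cccnc2F)c1F` stands lowest of the two numbers in a functional assay on the whole organism (strain Jcl:Sprague-Dawley) for inhibition, with Rattus norvegicus as the target, with stated times of 3 min and 3 h, at a dose of 1 mg/kg by the intravenous route (a lower number here means less inhibition, a higher number more inhibition at the dose given (going by the name of the read-out)), where compound 3 gives 87%. The nearest is compound 1 `CNCc1cn(S(=O)(=O)c2cccc(OC)n2)c(-c2cccnc2F)c1F`, which in this assay gives 98%; for compound 2 `CNCc1cn(S(=O)(=O)c2cccc(F)n2)c(-c2cccnc2F)c1F` this assay gives "not determined" (no result reported), so no result is reported for it. Among the measured compounds shown here, the single measured step, a number 11 percentage points lower from compound 1 to compound 3 (beyond the scatter), exchanges the ring on the sulfonyl sulfur and went a modest way beyond the scatter. Compound 4 `CNCc1cn(S(=O)(=O)c2cnccc2C)c(-c2cccnc2F)c1F` differs from compound 3 in that same place: 4-methylpyridin-3-yl in place of 5-fluoropyridin-2-yl on a sulfonyl sulfur. For the measured compounds named here, with only that one step as a guide, another exchange of the ring on the sulfonyl sulfur is expected to move the read-out in this assay only a little, possibly within the scatter, in either direction. Compound 4 is therefore expected at 80%, with a range of 55% to 97%. The expected step is a number 7 percentage points lower from compound 3 to compound 4 (within the scatter).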

Compound 4, a percentage reported as inhibition, in the whole organism at one dose (the size of the read-out at that dose, not a potency): 98%
Estimate against measurement, compound 4: 18 percentage points below; the whole stated range lies below it.
By their numbers in this assay, from the lowest: compound 3; then compounds 1 and 4 (each within the scatter of the next).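

In this assay, the sulfonyl sulfur accepts 4-methylpyridin-3-yl with no change at the digits printed from compound 1 to compound 4 (within the scatter), so a ring joined through its 3-position reads the same as the 6-methoxypyridin-2-yl of the earlier compound. The lower read-out of 5-fluoropyridin-2-yl now stands alone among the numbers, with a number 11 percentage points higher from compound 3 to compound 4 (beyond the scatter). No measured evidence bears on the reason for this difference.

Open, on these data alone, is whether the fluorine itself accounts for the lower read-out of compound 3. Also open, as far as these compounds go, is how the read-out responds to a ring carrying an amine or a carboxylic acid on the sulfonyl sulfur.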